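The compounds below may be only part of what the source reports. "The series", "measured", "known", "first", "only" and "open" are said of these compounds alone.

Values in a functional assay on PC-3 cells (Homo sapiens) for inhibition, read by sulforhodamine B assay, with a stated time of 48 h; a lower number here means a stronger inhibitor of growth, a higher number a weaker inhibitor of growth:
- compound 1 `CC1(/C=C/c2ccccc2)C=CC(=O)O1` gives 86900 nM
- compound 2 `CC1(/C=C/c2ccc(C(F)(F)F)cc2)C=CC(=O)O1` gives 13100 nM
- compound 3 `CC1(/C=C/c2ccc(F)cc2)C=CC(=O)O1` gives 46500 nM

Compound 3 cannot be separated from compound 1, as the measured step shows: a 1.9-fold lower number from compound 1 to compound 3 (0.27 log units; within the scatter). It stands clearly apart from compound 2: a 3.5-fold higher number from compound 2 to compound 3 (0.55 log units; beyond the scatter). Compound 4 `CC1(/C=C/c2ccc(O)cc2)C=CC(=O)O1` carries one change, (hydroxy in place of fluoro on an aromatic carbon), hydroxy in place of fluoro on an aromatic carbon. Within the data shown here, no measured compound carries hydroxy, so the evidence is indirect. Only trifluoromethyl moved the number beyond the scatter: a 6.6-fold lower number from compound 1 to compound 2 (0.82 log units; beyond the scatter). Fluoro did not, so a small substituent swap is expected to do little in this assay. The estimated change, expected to stay within the scatter, is a 1.2-fold higher number from compound 3 to compound 4 (0.07 log units; within the scatter). For compound 4 the expected value is 55000 nM, with an estimated range of 20000 nM to 130000 nM.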

Compound 4, concentration for total growth inhibition: 138000 nM
Estimate against measurement, compound 4: 2.5-fold (0.40 log units) below; the whole stated range lies below it.
By their numbers in this assay, from the lowest: compound 2; then compounds 3, 1 and 4 (each within the scatter of the next, the first and the last beyond it).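

In this assay, hydroxy and fluoro are not interchangeable on this aromatic carbon, even though each is a single heavy atom: a 3.0-fold higher number from compound 3 to compound 4 (0.47 log units; beyond the scatter). Hydroxy cannot be told apart from hydrogen here, a 1.6-fold higher number from compound 1 to compound 4 (0.20 log units; within the scatter), so it gives no sign of the gain seen with trifluoromethyl. Against trifluoromethyl, the step is the largest in the set: an 11-fold higher number from compound 2 to compound 4 (1.02 log units; beyond the scatter).

Nothing measured here explains the gap between hydroxy and fluoro. Also open, from the compounds shown here alone, is how a methoxy group or an amine on this carbon would compare with trifluoromethyl.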